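Cytotoxicity notes on four related compounds

This account rests on a few compounds, and the source may have more. Where it says the series, first, only, none or still open, it means among the compounds named here.

Measured so far:
- compound 1, `CC(=O)Nc1ccc(-c2nc3cc(C(F)(F)F)ccc3n2C)cc1`: > 100000 nM
- compound 2, `CC(=O)Nc1ccc(-c2nc3cc(C(F)(F)F)ccc3[nH]2)cc1`: 50000 nM
- compound 3, `Cn1c(-c2ccc(NC(=O)CN3CCCCC3)cc2)nc2cc(C(F)(F)F)ccc21`: > 100000 nM

All values come from an ADME assay on Vero cells (Chlorocebus sabaeus) for cytotoxicity; on this read-out higher numbers stand for lower toxicity in this test and lower numbers for higher toxicity in this test. For compound 1 the value > 100000 nM is a limit of the assay, not a number. For compound 3 the value > 100000 nM is likewise a limit. Compound 2 gives a number, 50000 nM.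

Between compound 1 and compound 2 the change is hydrogen in place of methyl on an aromatic nitrogen. The step measured is an at least 2.0-fold lower number from compound 1 to compound 2 (0.30 log units; that floor lies within the scatter); its floor sits within the scatter, so the true size is open.

The two cores differ as piperidin-1-yl in place of hydrogen on a saturated chain carbon bound to a carbonyl carbon. The step that the two limits leave unreadable from compound 1 to compound 3 cannot be read, because the limit of > 100000 nM in this assay, at which 2 of the 3 values shown sit, holds both ends.

Compound 4, `O=C(CN1CCCCC1)Nc1ccc(-c2nc3cc(C(F)(F)F)ccc3[nH]2)cc1`, is not yet measured. It differs from compound 3 as hydrogen in place of methyl on an aromatic nitrogen, the same change as that made from compound 1 to compound 2, since both place descriptions agree word for word. For compound 4 in this assay the step from its neighbour is expected as an at least 1.6-fold lower number from compound 3 to compound 4 (0.22 log units; that floor lies within the scatter), resting on the earlier step of an at least 2.0-fold lower number from compound 1 to compound 2 (0.30 log units; that floor lies within the scatter) and on the limit that compound 3 shows. Compound 4 is therefore estimated at 60000 nM, expected to lie between 20000 nM and 150000 nM, with a fair chance that only a limit is reported.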

Compound 4, half-maximal cytotoxic concentration: 31000 nM
Beside the measured number, compound 4's estimate is 1.9-fold (0.29 log units) above it; low and high end bracket the measured number.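

Carried to the core of compound 3, hydrogen in place of methyl on an aromatic nitrogen gives in this assay an at least 3.2-fold lower number from compound 3 to compound 4 (0.50 log units; beyond the scatter), so a lower number recurs on the second core, here with a floor beyond the scatter. This shows that the change can be carried to a core bearing piperidin-1-yl without the number moving the other way, but it does not show that the change has the same size on both cores: the same change on two cores in this assay, an at least 2.0-fold lower number (0.30 log units; that floor lies within the scatter) from compound 1 to compound 2 and an at least 3.2-fold lower number (0.50 log units; beyond the scatter) from compound 3 to compound 4; the limit leaves it open whether they differ The step from compound 1 to compound 3 cannot be read, and both steps for this change remain floors rather than sizes: the limit of > 100000 nM in this assay, at which 2 of the 4 values shown sit.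

With hydrogen on the aromatic nitrogen, piperidin-1-yl in place of hydrogen on a saturated chain carbon bound to a carbonyl carbon gives a 1.6-fold lower number from compound 2 to compound 4 (0.21 log units; within the scatter), which leaves open whether that group makes any difference in this test on this core. Also open, as far as these compounds go, is how the numbers in this assay would run with ethyl in place of methyl on the aromatic nitrogen, or with morpholine or a primary amine in place of piperidin-1-yl on the chain.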